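The source may hold more compounds than are shown below. What is called first, only, known or untested is meant among the compounds shown, and "the series" means these compounds.

Measured compounds:
Compound 1, `C[C@H](NC(=O)c1c(C2CCCCC2)nnn1Cc1ccc(C(F)(F)F)cc1)c1ccc(C(=O)O)cc1`, gives 161 nM in a functional assay on CHO cells for antagonist activity at prostaglandin E2 receptor EP4 subtype (Homo sapiens), read by calcium flux, with a stated time of 15 min; a lower number here means a stronger inhibitor, a higher number a weaker inhibitor.
Compound 2, `C[C@H](NC(=O)c1c(C2=CCCCC2)nnn1Cc1ccc(C(F)(F)F)cc1)c1ccc(C(=O)O)cc1`, gives 183 nM in this assay.

Compound 2 carries the higher of the two numbers, but the gap is small: the step of a 1.1-fold higher number from compound 1 to compound 2 (0.06 log units; within the scatter) lies within the scatter, so the two compounds cannot be ordered.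

Compound 3 is `Cc1ccc(-c2nnn(Cc3ccc(C(F)(F)F)cc3)c2C(=O)N[C@@H](C)c2ccc(C(=O)O)cc2)s1`. It differs from compound 2 by 5-methylthiophen-2-yl in place of cyclohex-1-en-1-yl on an aromatic carbon, on the ring carbon next to the ring nitrogen, two ring bonds from the ring atom that bears a 4-(trifluoromethyl)benzyl group.

For the measured compounds named here, only the step from compound 1 to compound 2 has been measured, and it swapped one six-membered carbon ring for another, which says little about an aromatic heterocycle entering at the same place. No direction can be drawn from it. Compound 3 is therefore expected to lie close to compound 2, with an estimated step of a 1.1-fold lower number from compound 2 to compound 3 (0.03 log units; within the scatter). The estimate for compound 3 is 170 nM, within the range 60 nM to 500 nM.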

Compound 3, half-maximal inhibitory concentration: 4.6 nM
The estimate for compound 3 lay 37-fold (1.57 log units) above the measured number; measured number outside the range, below it.
By their numbers in this assay, from the lowest: compound 3; then compounds 1 and 2 (each within the scatter of the next).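

In this assay, the aromatic carbon two ring bonds from the ring atom that bears a 4-(trifluoromethyl)benzyl group proves far more sensitive to its substituent than the swap between the two carbon rings suggested: 5-methylthiophen-2-yl in place of cyclohex-1-en-1-yl gives a 40-fold lower number from compound 2 to compound 3 (1.60 log units; beyond the scatter), and in place of cyclohexyl it gives a 35-fold lower number from compound 1 to compound 3 (1.54 log units; beyond the scatter). The groups exchanged between compound 2 and compound 3 both hold 6 heavy atoms, so that count does not track the change. Nothing available explains why this group does so much better.

As far as these compounds go, it remains open whether the gain belongs to the aromatic ring, its sulfur or its methyl, as these enter together in compound 3. A phenyl or an unsubstituted thiophen-2-yl at this place would begin to separate them.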